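Swapping the Aryl Group on the Amine Nitrogen

This account rests on a few compounds, and the source may have more. Where it says the series, first, only, none or still open, it means among the compounds named here.

Compound 2 `COc1ccccc1NC1=CC(=O)c2nc3n(c2C1=O)[C@H]1OC[C@@H](O)[C@H]1OC3` is one of two compounds tested in a functional assay on MCF7 cells (Homo sapiens) for inhibition, read by sulforhodamine B assay; on this read-out lower numbers stand for stronger inhibition and higher numbers for weaker inhibition. Its result is a limit of the assay rather than a number: compound 2 gives > 4000 nM. Compound 1 `O=C1C(Nc2ccc(I)cc2)=CC(=O)c2c1nc1n2[C@H]2OC[C@@H](O)[C@H]2OC1`, built on the same shared core, gives 3890 nM in this assay. Compound 3 `O=C1C=C(Nc2ccc(I)cc2)C(=O)c2c1nc1n2[C@H]2OC[C@@H](O)[C@H]2OC1` has not yet been measured in this assay. It differs from compound 2 by 4-iodophenyl in place of 2-methoxyphenyl on an amine nitrogen. Because compound 2 sits at the limit (the limit of > 4000 nM in this assay, at which 1 of the 2 values shown sits), the measured pair yields no step size. The expected step is an at least 1.0-fold lower number from compound 2 to compound 3 (0.02 log units; that floor lies within the scatter), not beyond the scatter. Compound 3 is estimated at 3800 nM, between 1500 nM and 9000 nM.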

Compound 3, half-maximal inhibitory concentration: 2230 nM
Compound 3: middle estimate off by 1.7-fold (0.23 log units), on the high side; the range from low to high includes it.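

Replacing 2-methoxyphenyl with 4-iodophenyl on this amine nitrogen turns a limit of this assay into a measured number, with an at least 1.7-fold lower number from compound 2 to compound 3 (0.25 log units; that floor lies within the scatter) as the only size that can be stated. The step remains a floor because compound 2 stands at a limit of the assay: the limit of > 4000 nM in this assay, at which 1 of the 3 values shown sits.

The compounds shown leave open how phenyl, 4-methoxyphenyl or 2-iodophenyl would read on this nitrogen. The contribution of the iodine therefore cannot be separated from that of the lost methoxy group or from where each group sits on the ring.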